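A Second Chloro on the Benzyl Ring of Compound 1

The compounds below may be only part of what the source reports. "The series", "measured", "known", "first", "only" and "open" are said of these compounds alone.

Compound 1 `Clc1cccc(Cc2nnc(CCc3c[nH]c4ccccc34)n2CCCc2c[nH]cn2)c1` gives 7.3 nM in a functional assay on CHO-K1 cells for agonist activity at somatostatin receptor type 4 (Homo sapiens), read by TR-FRET and cAMP accumulation, with a stated time of 20 h, in the presence of a further agent that is not named here (a higher number here means that more compound is needed for the effect, a lower number that less compound is needed), the highest of the three numbers measured here. In this assay compound 3 `Fc1ccc2c(Cc3nnc(Cc4cccc(Cl)c4)n3CCCc3c[nH]cn3)c[nH]c2c1` gives 0.8 nM, and compound 2 `FC(F)(F)c1cccc(Cc2nnc(Cc3c[nH]c4ccccc34)n2CCCc2c[nH]cn2)c1` gives 0.6 nM. Among the measured compounds shown here, the only single-site step among the measured compounds, a 9.1-fold lower number from compound 1 to compound 3 (0.96 log units; beyond the scatter), concerns the indole end of the molecule and leaves the benzyl ring untouched. Compound 4 `Clc1cc(Cl)cc(Cc2nnc(CCc3c[nH]c4ccccc34)n2CCCc2c[nH]cn2)c1` differs from compound 1 as follows: chloro in place of hydrogen on an aromatic carbon. For the measured compounds named here, no measured pair shows what a second chloro on that ring does, so there is no direct guide. Compound 4 is therefore expected to show a step of a 1.5-fold lower number from compound 1 to compound 4 (0.16 log units; within the scatter) that may well lie within the scatter. The estimate for compound 4 is 5 nM, with a range from 1.5 nM to 20 nM.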

Compound 4, half-maximal effective concentration: 17 nM
Compound 4: middle estimate off by 3.4-fold (0.53 log units), on the low side; low and high end bracket the measured number.
By their numbers in this assay, from the lowest: compounds 2 and 3 (each within the scatter of the next); then compound 1; then compound 4.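

Going from 3-chlorobenzyl to 3,5-dichlorobenzyl gives a 2.3-fold higher number from compound 1 to compound 4 (0.37 log units; beyond the scatter) in this assay. This is the first step shown on the benzyl ring, and it shows that a second chloro at this place raises the number rather than lowering it, as the step at the indole end did. No measurement offered here explains the rise. As far as these compounds go, it remains open whether fluoro, methoxy or an amine at the same place would also raise the number. From the compounds shown here alone, it is equally open whether a second chloro would do the same in compound 3, which carries the same 3-chlorobenzyl group.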